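Methoxy to hydroxy on the chlorophenyl arm of compound 2

The source may report more compounds than this note shows. Statements on the series, on what has been measured and on what is new or still open speak of the compounds shown alone.

Two members of this series have been run in a functional assay on SK-OV-3 cells (Homo sapiens) for inhibition, read by sulforhodamine B assay, with a stated time of 48 h; on this read-out lower numbers stand for stronger inhibition of growth and higher numbers for weaker inhibition of growth. Compound 1 `O=C(Nc1cccc(-n2cc(-c3ccncc3)c(-c3ccc(Cl)c(O)c3)n2)c1)Nc1ccc(Cl)c(Cl)c1` reaches only a limit there, at > 32500 nM. Among the compounds with values here, compound 2 `COc1cc(-c2nn(-c3cccc(NC(=O)Nc4ccc(Cl)c(C(F)(F)F)c4)c3)cc2-c2ccncc2)ccc1Cl` is the one member with an actual number: in this assay compound 2 gives 13000 nM, so it stands as the only measured value. The other entry, that of compound 1, is a limit rather than a figure. Within the data shown here, no step between measured compounds that differ in a single place is available, the two measured compounds differing in more than one place.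

Compound 3 `O=C(Nc1cccc(-n2cc(-c3ccncc3)c(-c3ccc(Cl)c(O)c3)n2)c1)Nc1ccc(Cl)c(C(F)(F)F)c1` is not yet measured. It follows from compound 2 by hydrogen in place of methyl on an oxygen on an aromatic ring. Among the measured compounds shown here, with no single-place step to lean on, and with the hydroxy-bearing compound 1 sitting at the limit of > 32500 nM in this assay, at which 1 of the 2 values shown sits, the expectation for compound 3 is a step from compound 2 toward weaker growth inhibition, of a size that may go beyond the usual scatter, a 1.9-fold higher number from compound 2 to compound 3 (0.28 log units; within the scatter). Compound 3 is therefore estimated at 25000 nM, with a range from 9000 nM to 60000 nM, and a real chance that compound 3 returns only a limit.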

Compound 3, concentration for total growth inhibition: 14900 nM
Compound 3: middle estimate off by 1.7-fold (0.22 log units), on the high side; the measured number falls inside the stated range.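

In this assay, methoxy to hydroxy on the chlorophenyl arm, with the trifluoromethyl group kept on the other arm, gives a 1.1-fold higher number from compound 2 to compound 3 (0.06 log units; within the scatter), so at this oxygen, hydrogen in place of methyl leaves the reading unchanged within the scatter, and the hydroxy group alone does not account for the weak reading of compound 1. Compound 1 remains a limit, not a number, and is the only such entry in this set: the limit of > 32500 nM in this assay, at which 1 of the 3 values shown sits. The difference that does register lies on the other arm, where trifluoromethyl in place of chloro on an aromatic carbon gives an at least 2.1-fold lower number from compound 1 to compound 3 (0.33 log units; beyond the scatter), a size that is only a bound.

Still open, as far as these compounds go, is whether a longer chain on that oxygen, or an amine in place of the hydroxy, would stay level with compound 2 and compound 3 in this assay. Also open, from the compounds shown here alone, is whether the step from chloro to trifluoromethyl holds with methoxy rather than hydroxy on the chlorophenyl arm.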